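The source may report more compounds than this note shows. Statements on the series, on what has been measured and on what is new or still open speak of the compounds shown alone.

Measured so far in a functional assay on the whole organism with Mus musculus as the target; on this read-out lower numbers stand for an effect already at smaller amounts and higher numbers for an effect only at larger amounts of compound:
Compound 1 (`Oc1ccnc(SCc2cccnc2)n1`): 456000 umol/kg
Compound 2 (`Nc1cc(O)nc(SCc2cccnc2)n1`): 8930 umol/kg

Of these two, compound 2 has the lower number, so it shows its effect at the smaller dose. Compound 3 (`Nc1cc(O)nc(SCc2ccc(Cl)nc2)n1`) has not yet been measured. It differs from compound 2 by a single change (chloro in place of hydrogen on an aromatic carbon), with chloro in place of hydrogen on an aromatic carbon. Among the compounds with values here, the only measured step (a 51-fold lower number from compound 1 to compound 2 (1.71 log units; beyond the scatter)) is large and beyond the scatter, but it concerns amino in place of hydrogen, a different group elsewhere in the molecule. Within the data shown here, no measured compound carries a chloro, so that step offers little guidance, and no step beyond the scatter is expected in this assay here. The expected step (a 1.5-fold lower number from compound 2 to compound 3 (0.17 log units; within the scatter)) is therefore small. For compound 3 the estimated value is 6000 umol/kg (expected range 1500 umol/kg to 20000 umol/kg).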

Compound 3, dose for half-maximal effect: 8300 umol/kg
Compound 3: middle estimate off by 1.4-fold (0.14 log units), on the low side; the measured number falls inside the stated range.
By their numbers in this assay, from the lowest: compounds 3 and 2 (each within the scatter of the next); then compound 1.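

In this assay, chloro in place of hydrogen on an aromatic carbon, next to the ring nitrogen, gives a 1.1-fold lower number from compound 2 to compound 3 (0.03 log units; within the scatter) and so leaves compound 2 and compound 3 level on this read-out. This position therefore accepts a chloro with no step beyond the scatter, unlike the change elsewhere in the molecule, the amino group that gave a 51-fold lower number from compound 1 to compound 2 (1.71 log units; beyond the scatter) and showed how strongly this read-out can respond to a single change. Nothing measured here offers an explanation for this result.

Going by these compounds, whether this tolerance holds only for chloro remains open, since an amine, a methoxy group or a carboxylic acid at this same position could behave differently. Fluoro or bromo at this position would show whether other halogens also stay within the scatter.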